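The source may report more compounds than this note shows. Statements on the series, on what has been measured and on what is new or still open speak of the compounds shown alone.

Compound 2 `CCOC(=O)c1c(C)nc(NCCCNc2ccnc3cc(Cl)ccc23)nc1-c1ccccc1` is one of three compounds tested in an ADME assay on Vero cells (Chlorocebus sabaeus) for cytotoxicity, read by microscopy; a higher number here means that more compound is tolerated, a lower number that less compound is tolerated. In this assay compound 2 gives 100000 nM. Compound 3 `Cc1nc(NCCNc2ccnc3cc(Cl)ccc23)nc(-c2ccccc2[N+](=O)[O-])c1C(=O)OC(C)C` gives 100000 nM in this assay, level with compound 2 at the digits shown and within the scatter. Compound 1 `CCOC(=O)c1c(C)nc(NCCCCNc2ccnc3cc(Cl)ccc23)nc1-c1ccccc1` gives > 100000 nM in this assay, which is a limit of the assay rather than a number; (the limit of > 100000 nM in this assay, at which 1 of the 3 values shown sits). Compound 4 `CCOC(=O)c1c(C)nc(NCCCNc2ccnc3cc(Cl)ccc23)nc1C` has not yet been measured in this assay. It differs from compound 2 in one place: methyl in place of phenyl on an aromatic carbon. Among the measured compounds shown here, no step between measured compounds is available to set the size of this change. Compound 4 is expected to show a step of no change at the digits printed from compound 2 to compound 4 (within the scatter), no change beyond the scatter. The estimate for compound 4 in this assay is 100000 nM, with a range from 50000 nM to 200000 nM.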

Compound 4, minimum cytotoxic concentration: > 100000 nM
Compound 4: no number, only a limit; the forecaster's own chance of this, stated with the estimate: 40%; the middle value lies on the limit itself.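

In this assay, methyl in place of phenyl on this aromatic carbon, ortho to an ethoxycarbonyl group, gives a number no lower from compound 2 to compound 4 (the limit leaves the size open). Among the compounds shown here, this is the first step seen at this position, and it shows that removing the phenyl ring does not lower the tolerated concentration. The step ends in a limit of the assay, and its size stays unread: the limit of > 100000 nM in this assay, at which 2 of the 4 values shown sit.

The compounds shown leave open whether an amine or a carboxylic acid on this carbon would lower the number. They also leave open what an ethyl group there would give.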